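The compounds below may be only part of what the source reports. "The series", "measured", "known", "first", "only" and "open" are said of these compounds alone.

Measured compounds and their values:

- Compound 1, `CCOC(=O)c1c(C)nc(-c2cccc(C#N)c2)n1O`: 17600 nM
- Compound 2, `C=CCOn1c(-c2cccc(C#N)c2)nc(C)c1C(=O)OCC`: 5860 nM
- Compound 3, `CCOC(=O)COn1c(-c2cccc(C#N)c2)nc(C)c1C(=O)OCC`: 6800 nM

Compound 2 gives the lowest number of the three in a functional assay on a cell-free system (plasma, Oryctolagus cuniculus) for inhibition, with stated times of 5 min, 1 min and 6 min (a higher number here means a weaker inhibitor, a lower number a stronger inhibitor), yet its lead over compound 3 is small: the step of a 1.2-fold higher number from compound 2 to compound 3 (0.06 log units; within the scatter) lies within the scatter, so the two cannot be ordered. Only compound 1, which carries hydrogen on the oxygen on the aromatic ring, stands apart, as shown by a 3.0-fold lower number from compound 1 to compound 2 (0.48 log units; beyond the scatter) and a 2.6-fold lower number from compound 1 to compound 3 (0.41 log units; beyond the scatter).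

Compound 4, `CCOC(=O)c1c(C)nc(-c2cccc(C#N)c2)n1OCc1ccccc1C#N`, has not yet been tested in this assay. It differs from compound 2 by 2-cyanophenyl in place of vinyl on a saturated chain carbon bound to an oxygen on an aromatic ring.

Two of the measured steps bear on this change. The step from compound 2 to compound 3 is the closest match, since it also swaps the group on the saturated chain carbon bound to the oxygen on the aromatic ring, and it produced no step beyond the scatter. The steps from compound 1 show that having something other than hydrogen on that oxygen matters modestly, and compound 4 keeps such a group. Among the measured compounds shown here, no measured compound carries an aromatic ring at this position, so the effect of the 2-cyanophenyl itself is unknown.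

Compound 4 is therefore expected to stay close to compound 2, with a 1.2-fold lower number from compound 2 to compound 4 (0.07 log units; within the scatter) predicted to fall within the scatter, giving an estimate of 5000 nM with a range from 1500 nM to 16000 nM.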

Compound 4, half-maximal inhibitory concentration: 9380 nM
Estimate against measurement, compound 4: 1.9-fold (0.27 log units) below; low and high end bracket the measured number.
By their numbers in this assay, from the lowest: compounds 2, 3, 4 and 1 (each within the scatter of the next, the first and the last beyond it).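

In this assay, an aromatic ring at this position, entering as 2-cyanophenyl on the saturated chain carbon bound to the oxygen, gives no step beyond the scatter against either vinyl (a 1.6-fold higher number from compound 2 to compound 4 (0.20 log units; within the scatter)) or ethoxycarbonyl (a 1.4-fold higher number from compound 3 to compound 4 (0.14 log units; within the scatter)), so all three groups remain unordered there. Unlike allyl and (ethoxycarbonyl)methyl, however, 2-cyanobenzyl does not stand clearly apart from hydrogen on that oxygen (a 1.9-fold lower number from compound 1 to compound 4 (0.27 log units; within the scatter)), which leaves compound 4 within the scatter of all three other compounds, even though compound 1 stays separated from compound 2 and compound 3. No measurement is at hand that would account for these numbers.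

The compounds shown leave open whether the nitrile of the 2-cyanobenzyl group matters at all, a question that a plain benzyl group on the same oxygen would address. They also leave open whether an amine or a carboxylic acid at the end of a longer chain on that oxygen would move the number beyond the scatter.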